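A Diethylamino Variant of the Shared Core

This account rests on a few compounds, and the source may have more. Where it says the series, first, only, none or still open, it means among the compounds named here.

compound 1 `O=C(c1cc(Cc2n[nH]c(=O)c3ccccc23)ccc1F)N1CCc2nc(Cl)ncc2C1` — "nd" (no result reported)
compound 2 `CN1CCN(c2ncc3c(n2)CCN(C(=O)c2cc(Cc4n[nH]c(=O)c5ccccc45)ccc2F)C3)CC1` — > 200000 nM
compound 3 `O=C(c1cc(Cc2n[nH]c(=O)c3ccccc23)ccc1F)N1CCc2nc(N3CCCCC3)ncc2C1` — > 200000 nM

Compound 3 stands only at a limit in a functional assay on MDA-MB-231 cells (Homo sapiens) for inhibition, read by MTT assay, with a stated time of 48 h; a lower number here means a stronger inhibitor, a higher number a weaker inhibitor: compound 3 gives > 200000 nM, which is a limit of the assay and not a number. Compound 2 likewise gives only a limit, > 200000 nM. For compound 1 no result was reported. Within the data shown here, the single step between measured compounds, a step that the two limits leave unreadable from compound 2 to compound 3, lies between two limits and has no readable size; the limit of > 200000 nM in this assay, at which 2 of the 3 values shown sit, marks where both sit. Compound 4 `CCN(CC)c1ncc2c(n1)CCN(C(=O)c1cc(Cc3n[nH]c(=O)c4ccccc34)ccc1F)C2` differs from compound 3 by diethylamino in place of piperidin-1-yl on an aromatic carbon. No measured step gives a size for this change, and nothing shown points away from the limit. Compound 4 is expected to sit at 250000 nM, within 100000 nM to 1000000 nM. The step that the limit leaves unreadable from compound 3 to compound 4 is thus expected to be none beyond the scatter.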

Compound 4, half-maximal inhibitory concentration: > 200000 nM
Compound 4: only a limit was reported; the forecaster's own chance of this, stated with the estimate: 85%; the middle value lies beyond the limit too.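

In this assay compound 4 gives > 200000 nM, which is a limit of the assay and not a number, and the steps among compound 2, compound 3 and compound 4 cannot be read. The compounds shown leave open how these three differ, if at all, past the limit they share: the limit of > 200000 nM in this assay, at which 3 of the 4 values shown sit.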